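The source may hold more compounds than are shown below. What is called first, only, known or untested is meant among the compounds shown, and "the series" means these compounds.

Measured so far:
- compound 1, `COc1ccc2ncc(S(=O)(=O)c3ccc(OC)c(Cl)c3)c(N3CCC(C)CC3)c2c1`: 21%
- compound 2, `COc1ccc(S(=O)(=O)c2cnc3ccc(F)cc3c2N2CCC(C)CC2)cc1Cl`: 82%

Among the compounds with values here, in an assay on isolated protein for displacement of a labelled ligand from metabotropic glutamate receptor 5 (Homo sapiens), with a stated time of 60 min, tested at 1 uM (on this read-out lower numbers stand for less inhibition and higher numbers for more inhibition at the one concentration tested (going by the name of the read-out)), compound 1 gives 21%, the lowest of the two numbers recorded; its nearest neighbour is compound 2, and the single measured step is a number 61 percentage points higher from compound 1 to compound 2 (beyond the scatter), a large rise brought by fluoro in place of methoxy on an aromatic carbon of the shared core.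

Compound 3, `COc1ccc2ncc(S(=O)(=O)c3ccc(C)cc3)c(N3CCC(C)CC3)c2c1`, has not yet been measured in this assay. It departs from compound 1 by a different route: 4-methylphenyl in place of 3-chloro-4-methoxyphenyl on a sulfonyl sulfur. Within the data shown here, this alters the group carried on the sulfonyl sulfur, whereas the one measured step changes a group on the core and leaves the sulfonyl side untouched. Among the measured compounds shown here, no measured pair therefore speaks to this change, and its direction cannot be read from the two numbers at hand.

For the measured compounds named here, with no guiding step, the expected outcome for compound 3 is a small movement from compound 1, a number 9 percentage points higher from compound 1 to compound 3 (within the scatter), that may fall inside the usual scatter in either direction. The estimate for compound 3 in this assay is 30%, within a broad range from 5% to 70%.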

Compound 3, a percentage reported as inhibition, at one concentration (the size of the read-out at that concentration, not a potency): 90%
Compound 3: the middle estimate sits 60 percentage points below what was measured; the measured number lies above the stated range.
By their numbers in this assay, from the lowest: compound 1; then compounds 2 and 3 (each within the scatter of the next).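

In this assay, within the data shown here, 4-methylphenyl in place of 3-chloro-4-methoxyphenyl on a sulfonyl sulfur gives a number 69 percentage points higher from compound 1 to compound 3 (beyond the scatter), so the sulfonyl side, which no earlier pair touched, can move this read-out by a large amount. The core group of compound 1 therefore does not fix the low number on its own: that methoxy stays in place here, whereas the earlier rise, a number 61 percentage points higher from compound 1 to compound 2 (beyond the scatter), came from changing it, and this new change removes chloro and methoxy together while bringing in methyl, so one step cannot be shared out among them. No measurement at hand says why the number rises.

The compounds shown leave open how 3-chlorophenyl, 4-methoxyphenyl or plain phenyl on the sulfonyl sulfur would read, and those groups would separate the part played by each substituent. Also open, on these data alone, is what happens when fluoro on the core is combined with 4-methylphenyl on the sulfonyl sulfur, and whether a single-concentration reading of this kind would carry over to a full potency measurement.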